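A few compounds are considered here, and "the series" means these few. Any claim that something is new, unique, unknown or untested is made for them only; others in the source may bear on it.

Measured in a physicochemical assay for acid dissociation:
- compound 1 `NS(=O)(=O)c1ccc(S(=O)(=O)CCCO)cc1`: 8.98
- compound 2 `NS(=O)(=O)c1ccc(S(=O)(=O)CC(O)CO)cc1`: 9.35
- compound 3 `NS(=O)(=O)c1ccc(SCCO)c(F)c1`: 9.76

Compound 1 has the lowest of these three numbers, with compound 2 nearest and compound 3 furthest. Compound 4 `NS(=O)(=O)c1ccc(S(=O)(=O)CCCO)c(C(=O)O)c1` keeps the core of compound 1 but carries carboxy in place of hydrogen on an aromatic carbon, meta to a sulfamoyl group (carboxy in place of hydrogen on an aromatic carbon). Among the compounds with values here, no measured step makes this change. Within the data shown here, the only step available, a number 0.37 log units higher from compound 1 to compound 2 (beyond the scatter), is modest and swaps hydroxy for hydrogen on a saturated chain carbon, so it is a loose guide. A small upward move in this assay is therefore expected, possibly no larger than the scatter: the estimate is a number 0.22 log units higher from compound 1 to compound 4 (within the scatter). For compound 4 the expected value is 9.2, with an estimated range from 8.7 to 9.8.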

Compound 4, acid dissociation constant: 9.28
Compound 4: middle estimate off by 0.08 log units, on the low side; the range from low to high includes it.
By their numbers in this assay, from the lowest: compounds 1, 4 and 2 (each within the scatter of the next, the first and the last beyond it); then compound 3.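

In this assay, carboxy in place of hydrogen on an aromatic carbon, ortho to a group of 7 heavy atoms and meta to a sulfamoyl group, gives a number 0.30 log units higher from compound 1 to compound 4 (within the scatter), so this measurement cannot tell the two compounds apart. This is the only listed step made on the aromatic ring, whereas the earlier step lay on the saturated chain. Nothing measured here bears on the reason for this result. An amine or a methyl ester at this same position could show whether another group gives a step beyond the scatter. The compounds shown also leave open whether carboxy would give a similar step on the core of compound 2.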